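A few compounds are considered here, and "the series" means these few. Any claim that something is new, unique, unknown or untested is made for them only; others in the source may bear on it.

Compound 1 `Cc1cnc(NC(=O)c2cc(Oc3cnc(C(=O)N(C)C)cn3)c3cc(C)oc3c2)cn1`: 176000 nM
Compound 2 `Cc1cnc(NC(=O)c2cc(Oc3ccc(C#N)cc3)c3cc(C)oc3c2)cn1`: 2000 nM

In a physicochemical assay for solubility, measured as kinetic solubility (on this read-out higher numbers stand for higher solubility and lower numbers for lower solubility), compound 1 holds the higher of the two numbers, and compound 2, at 2000 nM, lies lower by well beyond the usual scatter. Compound 3 `Cc1cnc(NC(=O)c2cc(Oc3cnc(C(=O)N4CCC4)cn3)c3cc(C)oc3c2)cn1` differs from compound 1 in one place, with azetidin-1-yl in place of dimethylamino on a carbonyl carbon. Going by the values given here, no measured pair shows this swap, so the expectation rests on compound 1 alone. The expected step in this assay is slightly downward and no larger than the scatter: a 1.3-fold lower number from compound 1 to compound 3 (0.10 log units; within the scatter). Compound 3 is estimated at 140000 nM, with an expected range from 50000 nM to 300000 nM.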

Compound 3, solubility: 10000 nM
The estimate for compound 3 lay 14-fold (1.15 log units) above the measured number; measured number outside the range, below it.
By their numbers in this assay, from the lowest: compound 2; then compound 3; then compound 1.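

In this assay, putting azetidin-1-yl in place of dimethylamino on a carbonyl carbon gives an 18-fold lower number from compound 1 to compound 3 (1.25 log units; beyond the scatter), so even a small change at this place can move the number well beyond the scatter. The step appears although the hydrogen-bond donor and acceptor counts of the two groups and their net charge are the same. Nothing available here accounts for its size. Still open, on these data alone, is whether a larger ring, such as pyrrolidin-1-yl or morpholin-4-yl, on this carbonyl carbon would lie nearer compound 1 or compound 3. Also open, as far as these compounds go, is whether the same swap would give a step of similar size on another core.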